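The source may hold more compounds than are shown below. What is called first, only, known or untested is meant among the compounds shown, and "the series" means these compounds.

Working notes on the series.

Two compounds of the shared core have numbers in an assay on isolated protein for inhibition of Maltase-glucoamylase (Homo sapiens), with a stated time of 15 min; on this read-out lower numbers stand for stronger inhibition and higher numbers for weaker inhibition. Compound 1 `O=C(N/N=C/c1ccc([N+](=O)[O-])cc1)c1ccc(-c2nc3ccccc3s2)cc1` gives 26400 nM. Compound 2 `O=C(N/N=C/c1ccc(Cl)cc1)c1ccc(-c2nc3ccccc3s2)cc1` gives 5310 nM. Among the measured compounds shown here, the single step between them, a 5.0-fold lower number from compound 1 to compound 2 (0.70 log units; beyond the scatter), is the only one measured so far, so compound 2 stands as the lower of the two numbers, with compound 1 as the only neighbour for comparison.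

Compound 3 `COc1cccc(/C=N/NC(=O)c2ccc(-c3nc4ccccc4s3)cc2)c1` is not yet measured. It differs from compound 2 in one place: 3-methoxyphenyl in place of 4-chlorophenyl on a carbon with a double bond to nitrogen. For the measured compounds named here, no measured step exchanges one substituted phenyl for another on this carbon; the one step that exists, from nitro to chloro, bears on it only in showing that the group on this phenyl can move the number in this assay by a modest amount. Nothing measured tells which way a methoxy group set on the 3-methoxyphenyl ring will move it, so the expectation is a step of a 1.5-fold higher number from compound 2 to compound 3 (0.18 log units; within the scatter) at most, near the scatter, with a slight lean toward a weaker number.

Compound 3 is therefore estimated at 8000 nM in this assay, within a range from 2500 nM to 25000 nM.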

Compound 3, half-maximal inhibitory concentration: 11100 nM
Beside the measured number, compound 3's estimate is 1.4-fold (0.14 log units) below it; the measured number falls inside the stated range.
By their numbers in this assay, from the lowest: compound 2; then compound 3; then compound 1.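

In this assay, the exchange of one substituted phenyl for another on a carbon with a double bond to nitrogen now has direct readings: 3-methoxyphenyl in place of 4-chlorophenyl gives a 2.1-fold higher number from compound 2 to compound 3 (0.32 log units; beyond the scatter), while 3-methoxyphenyl in place of 4-nitrophenyl gives a 2.4-fold lower number from compound 1 to compound 3 (0.38 log units; beyond the scatter). This place therefore separates all three groups beyond the scatter, with 3-methoxyphenyl lying between the other two, although both steps remain modest and each changes the group and its number on the ring together. No other measurement at hand bears on why the number moves.

The compounds shown leave open how much of the step from 4-chlorophenyl belongs to the change of group and how much to the change of ring number, a question that 4-methoxyphenyl and 3-chlorophenyl on the same carbon would separate. They also leave open whether an amine or a carboxylic acid on this phenyl would bring the number below that of compound 2, at 5310 nM.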